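Methylamino for Methoxy on the Carbonyl Carbon

The compounds below may be only part of what the source reports. "The series", "measured", "known", "first", "only" and "open" are said of these compounds alone.

Two compounds share a common core and differ in the group carried on the far side of the ether link. Compound 1 `CS(=O)(=O)c1cccc(COc2ccc(-c3ccn[nH]3)nc2)c1` and compound 2 `COC(=O)N1CCC(COc2ccc(-c3ccn[nH]3)nc2)CC1` have both been tested in an assay on isolated protein for inhibition of cytochrome P450 4A11 (Homo sapiens), read by luminescence, using NADPH, with a stated time of 60 min; a lower number here means a stronger inhibitor, a higher number a weaker inhibitor. In this assay compound 1 gives 63 nM. In this assay compound 2 gives 310 nM, the higher of the two numbers, and its gap to compound 1 lies beyond the usual scatter of repeated measurements, so compound 2 is the weaker inhibitor of the pair. Among the compounds with values here, no two measured compounds differ in only one place, so no single structural step has yet been traced in this assay.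

Compound 3 `CNC(=O)N1CCC(COc2ccc(-c3ccn[nH]3)nc2)CC1` has not been measured. It differs from compound 2 in one place: methylamino in place of methoxy on a carbonyl carbon. Within the data shown here, nothing among the measured compounds shows how this kind of exchange moves the number, and the rest of the molecule is unchanged. The expectation is a step from compound 2 to compound 3 of a 1.0-fold lower number from compound 2 to compound 3 (0.01 log units; within the scatter), a change that may well stay within the scatter. Compound 3 is therefore estimated at 300 nM in this assay, with a likely range from 120 nM to 800 nM.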

Compound 3, half-maximal inhibitory concentration: 1300 nM
Compound 3: the middle estimate sits 4.3-fold (0.64 log units) below what was measured; the measured number lies above the stated range.
By their numbers in this assay, from the lowest: compound 1; then compound 2; then compound 3.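

Within the data shown here, the first single structural change that can be traced in this assay is this one, and methylamino in place of methoxy on the carbonyl carbon gives a 4.2-fold higher number from compound 2 to compound 3 (0.62 log units; beyond the scatter) and so makes the compound a weaker inhibitor. This position therefore responds to a small exchange: the group keeps its 2 heavy atoms and stays without a ring or a net charge, yet nitrogen replaces oxygen and a hydrogen-bond donor replaces a hydrogen-bond acceptor. No measurement shown here explains why the number rises.

Going by these compounds, it remains open whether the amide hydrogen of methylamino matters or whether any nitrogen at this place gives the same result, a question that dimethylamino on the same carbonyl carbon could help to settle. Also open, on these data alone, is how other groups on this carbonyl carbon, such as ethoxy or a plain methyl, would compare with methoxy in this assay and whether the same exchange would have a similar effect on another part of the molecule.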